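Hydroxymethyl in Place of Carboxy in Two Compounds

The source may report more compounds than this note shows. Statements on the series, on what has been measured and on what is new or still open speak of the compounds shown alone.

Measured so far in an assay on Sf9 cells for inhibition of histone deacetylase 11 (Homo sapiens), read by fluorescence, tested at 0.5 uM; on this read-out higher numbers stand for more inhibition at the one concentration tested (going by the name of the read-out) and lower numbers for less inhibition:
Compound 1 `O=C(NO)c1ccc(-c2cn([C@@H]3C[C@@H](CO)N(CCCc4ccccc4)C3)nn2)cc1` gives 14%.
Compound 2 `O=C(NO)c1ccc(-c2cn([C@@H]3C[C@@H](C(=O)O)N(CCCc4ccccc4)C3)nn2)cc1` gives 14%.
Compound 3 `O=C(NO)c1ccc(-c2cn([C@H]3C[C@H](C(=O)O)N(Cc4ccccc4)C3)nn2)cc1` is reported only as a limit of the assay, < 10%.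

All three compounds share a common core and differ only at the five-membered non-aromatic ring and its substituents. Compound 2 and compound 1 differ in one place, (hydroxymethyl in place of carboxy on a saturated ring carbon), and this change gave no change at the digits printed from compound 2 to compound 1 (within the scatter). How the core of compound 3 differs from that of compound 2 is not broken down here. For compound 3 the assay reports no number, only a limit; its value sits at the limit of < 10% in this assay, at which 1 of the 3 values shown sits.

Compound 4 `O=C(NO)c1ccc(-c2cn([C@H]3C[C@H](CO)N(Cc4ccccc4)C3)nn2)cc1` has not yet been measured. It differs from compound 3 by hydroxymethyl in place of carboxy on a saturated ring carbon. For the measured compounds named here, this is the same kind of change as the one from compound 2 to compound 1, though the surroundings are not identical: in compound 3 the changed carbon is next to the ring atom that bears a benzyl group, whereas in compound 2 it is next to the ring atom that bears a 3-phenylpropyl group.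

In this assay the step from compound 3 to compound 4 is expected to be a step that the limit leaves unreadable from compound 3 to compound 4, because the same kind of change gave no change at the digits printed from compound 2 to compound 1 (within the scatter). Compound 4 is therefore estimated at 9%, with a range from 2% to 17%, and it may well again be reported only as a limit.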

Compound 4, a percentage reported as inhibition, at one concentration (the size of the read-out at that concentration, not a potency): 16%
Estimate against measurement, compound 4: 7 percentage points below, and the stated range covers the measured number.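

In this assay, hydroxymethyl in place of carboxy gave a number at least 6 percentage points higher from compound 3 to compound 4 (that floor lies within the scatter), and the two cases of this change read as follows: the same change on two cores in this assay, no change at the digits printed (within the scatter) from compound 2 to compound 1 and a number at least 6 percentage points higher (that floor lies within the scatter) from compound 3 to compound 4; the limit leaves it open whether they differ

Compound 3 stands at < 10%, which is a limit of the assay and not a number: the limit of < 10% in this assay, at which 1 of the 4 values shown sits.

Carried from the core of compound 2 to the core of compound 3, the change therefore gives no step printed as beyond the scatter, but the second step is known only as a floor, so its true size remains unread, and the result shows neither that the change acts alike on the two cores nor that it acts differently.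

The compounds shown leave open how an amine, an amide or a longer chain in the place of the hydroxymethyl, on the same saturated ring carbon, would read in this assay. They also leave open whether the same change would give a similar result with a group other than benzyl or 3-phenylpropyl on the ring atom that bears them, such as a longer chain ending in a phenyl ring.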